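This account rests on a few compounds, and the source may have more. Where it says the series, first, only, none or still open, it means among the compounds named here.

Going by the values given here, compound 1 `Cc1ccc(CC(C)C(=O)N2CCN(c3ccc(C(F)(F)F)cc3[C@@H](N)CC(C)C)CC2)cc1C` is the reference point of the two compounds measured so far. In an assay on HEK293 cells for displacement of a labelled ligand from Melanocortin receptor 4 (Homo sapiens) (a lower number here means a stronger inhibitor, a higher number a weaker inhibitor), compound 1 gives 240 nM, the lowest of the two numbers. Compound 2 `CC(C)C[C@H](N)c1cc(C(F)(F)F)ccc1N1CCN(C(=O)CCC2CCCCC2)CC1` is clearly weaker: in this assay compound 2 gives 5700 nM, and the step of a 24-fold higher number from compound 1 to compound 2 (1.38 log units; beyond the scatter) came from 2-cyclohexylethyl taking the place of 1-(3,4-dimethylbenzyl)ethyl on a carbonyl carbon. Among the compounds with values here, compound 3 `CC(C)C[C@H](N)c1cc(C(F)(F)F)ccc1N1CCN(C(=O)COc2cccc(Cl)c2Cl)CC1` is the next candidate. (2,3-dichlorophenoxy)methyl in place of 1-(3,4-dimethylbenzyl)ethyl on a carbonyl carbon The only measured step bearing on this change is a 24-fold higher number from compound 1 to compound 2 (1.38 log units; beyond the scatter). That step replaced the same leaving group, but with 2-cyclohexylethyl; here the entering group still carries one six-membered aromatic ring of carbon only, so a loss is expected, though a smaller one than with compound 2. The expected step is therefore a 3.3-fold higher number from compound 1 to compound 3 (0.52 log units; beyond the scatter). For compound 3 the estimate in this assay is 800 nM, with a range from 200 nM to 3000 nM.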

Compound 3, inhibition constant: 2500 nM
Compound 3: middle estimate off by 3.1-fold (0.49 log units), on the low side; measured number inside the range.
By their numbers in this assay, from the lowest: compound 1; then compound 3; then compound 2.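

In this assay, keeping one six-membered aromatic ring of carbon only on the carbonyl carbon does not hold the number of compound 1: (2,3-dichlorophenoxy)methyl gives a 10-fold higher number from compound 1 to compound 3 (1.02 log units; beyond the scatter). Set against the saturated group, 2,3-dichlorophenoxy in place of cyclohexylmethyl gives only a 2.3-fold lower number from compound 2 to compound 3 (0.36 log units; beyond the scatter), so among the three groups shown, 1-(3,4-dimethylbenzyl)ethyl keeps the lowest number and both replacements remain well short of it. Nothing at hand gives a reason for these differences.

Still open, going by these compounds, is whether the lower number of compound 1 follows the two ring methyl groups or the branched chain, and whether the ether oxygen of compound 3 counts separately from its two chlorines. On these data alone, how an amine or a carboxylic acid on this chain would read also remains open.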